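A few compounds are considered here, and "the series" means these few. Any claim that something is new, unique, unknown or untested is made for them only; others in the source may bear on it.

Compound 1 `Cc1ccc(-c2cn(C/C=C3\OC(=O)C(OCc4ccccc4)=C3OCc3ccccc3)nn2)cc1` belongs to a small set built on a shared core and tested in a functional assay on U-937 cells (Homo sapiens) for antiproliferative activity, read by MTT assay, with a stated time of 24 h; on this read-out higher numbers stand for weaker inhibition and lower numbers for stronger inhibition. In this assay compound 1 reaches only a limit, > 100000 nM, so its standing on the numbers shown is that of a compound with no measurable inhibition. Compound 2 `Cc1ccc(-c2cn(CCC3(O)NC(=O)C(OCc4ccccc4)=C3OCc3ccccc3)nn2)cc1` gives 54000 nM in this assay. Compound 3 `O=C1NC(O)(CCn2cc(C3=CCCCC3)nn2)C(OCc2ccccc2)=C1OCc1ccccc1` likewise returns only a limit, > 100000 nM. Among the measured compounds shown here, the single measured step between compounds differing in one place is an at least 1.8-fold higher number from compound 2 to compound 3 (0.26 log units; that floor lies within the scatter), an exchange at the same aromatic carbon but of a different kind, and its size is capped by the limit of > 100000 nM in this assay, at which 2 of the 3 values shown sit. Compound 4 `O=C1O/C(=C\Cn2cc(-c3ccccn3)nn2)C(OCc2ccccc2)=C1OCc1ccccc1` differs from compound 1 by pyridin-2-yl in place of 4-methylphenyl on an aromatic carbon. For the measured compounds named here, no measured step covers this exchange, and the one step at this position gave no gain in inhibition. Compound 4 is therefore expected to show a step of a number no higher from compound 1 to compound 4 (the limit leaves the size open), none beyond the scatter. The value of compound 4 in this assay is estimated at 100000 nM, in the range 40000 nM to 300000 nM.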

Compound 4, half-maximal inhibitory concentration: 70200 nM
The estimate for compound 4 lay 1.4-fold (0.15 log units) above the measured number; low and high end bracket the measured number.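

In this assay, pyridin-2-yl in place of 4-methylphenyl gives a step that can be read only in part: an at least 1.4-fold lower number from compound 1 to compound 4 (0.15 log units; that floor lies within the scatter) is all it shows. On the core of compound 1, this position therefore accepts a ring with one nitrogen and one hydrogen-bond acceptor and still yields a number, although that number is not shown to be better than the parent compound's. How large the step really is cannot be told, because one end of it is only a limit: the limit of > 100000 nM in this assay, at which 2 of the 4 values shown sit.

As far as these compounds go, whether pyridin-2-yl would act the same way on the core of compound 2 remains open. Also open, from the compounds shown here alone, is what a simple amine, a carboxylic acid or a longer alkyl chain at this position would give in this assay.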